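Compound 3: pyridin-4-yl on the aromatic nitrogen

The compounds below may be only part of what the source reports. "The series", "measured", "known", "first", "only" and "open" are said of these compounds alone.

- Compound 1 `CS(=O)(=O)NC(=O)CCc1cn(-c2cccc(Br)c2)nc1-c1ccc(Cl)cc1` gives < 5000 nM (a limit)
- Compound 2 `CS(=O)(=O)NC(=O)CCc1cn(-c2ccccc2Br)nc1-c1ccc(Cl)cc1` gives 165000 nM (a number)

Going by the values given here, in a physicochemical assay for solubility, in phosphate buffer, measured as thermodynamic solubility, at pH 7.4 (a lower number here means a less soluble compound, a higher number a more soluble compound), compound 2 gives 165000 nM as the only actual number so far. Compound 1 stands at < 5000 nM and that value is a limit of the assay, not a number.

Compound 3 `CS(=O)(=O)NC(=O)CCc1cn(-c2ccncc2)nc1-c1ccc(Cl)cc1` carries pyridin-4-yl in place of 2-bromophenyl on an aromatic nitrogen and keeps the rest of the core.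

Among the compounds with values here, one measured step touches this group, an at least 33-fold higher number from compound 1 to compound 2 (1.51 log units; beyond the scatter), and it is large. It only exchanges 3-bromophenyl for 2-bromophenyl, so it shows that this group can matter but gives no direction for a pyridin-4-yl group.

The expected step is a 1.5-fold lower number from compound 2 to compound 3 (0.18 log units; within the scatter), with no move beyond the scatter taken as the central case. For compound 3 the estimate is 110000 nM in this assay (expected range 15000 nM to 500000 nM) and the width of that range allows a large move either way.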

Compound 3, solubility: 190000 nM
Beside the measured number, compound 3's estimate is 1.7-fold (0.24 log units) below it; the measured number falls inside the stated range.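

In this assay, the position on the aromatic nitrogen accepts a ring with a hetero atom with no change beyond the scatter: the step is a 1.2-fold higher number from compound 2 to compound 3 (0.06 log units; within the scatter), so 2-bromophenyl and pyridin-4-yl cannot be told apart here. The step of an at least 38-fold higher number from compound 1 to compound 3 (1.57 log units; beyond the scatter) shows that a group without bromine also stands well apart from 3-bromophenyl, so the large gap is no longer seen only between the two bromophenyl groups. That step starts from the value of compound 1, which is a limit and not a number: the limit of < 5000 nM in this assay, at which 1 of the 3 values shown sits.

Still open, as far as these compounds go, is the true size of the gap to compound 1. Also open, from the compounds shown here alone, is whether 4-bromophenyl, pyridin-3-yl, or a phenyl ring carrying an amine or a carboxylic acid would stay level with compound 2 or fall toward compound 1.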